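The source may report more compounds than this note shows. Statements on the series, on what has been measured and on what is new or still open speak of the compounds shown alone.

Working notes on the series. Compound 1 `CS(=O)(=O)c1ccc(F)c(C#Cc2cc(Cl)ccc2OCC(=O)O)c1` and compound 2 `CCCS(=O)(=O)c1ccc(F)c(C#Cc2cc(Cl)ccc2OCC(=O)O)c1` are the two members with numbers in an ADME assay on a cell-free system (plasma, Homo sapiens); on this read-out lower numbers stand for a smaller free fraction and higher numbers for a larger free fraction. In this assay compound 1 gives 0.013, and compound 2 gives 0.01. For the measured compounds named here, the one recorded step, a 1.3-fold lower number from compound 1 to compound 2 (0.11 log units; within the scatter), is the only calibration available.

Going by these compounds, compound 3 `COCCNS(=O)(=O)c1ccc(C)c(C#Cc2cc(Cl)ccc2OCC(=O)O)c1` carries a sulfonamide rather than the alkyl sulfonyl of compound 1 and compound 2, and in this assay compound 3 gives "not determined" (no result reported), so its standing on this read-out is unknown. Compound 4 `Cc1ccc(S(=O)(=O)N(C)C(C)C)cc1C#Cc1cc(Cl)ccc1OCC(=O)O` is its direct partner: isopropyl(methyl)amino in place of (2-methoxyethyl)amino on a sulfonyl sulfur.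

Going by the values given here, no measured step bears directly on this change. Among the compounds with values here, the only step in hand, a 1.3-fold lower number from compound 1 to compound 2 (0.11 log units; within the scatter), concerns a different position and lies within the scatter, which shows that a small alkyl extension at the sulfonyl sulfur did not move the free fraction in a detectable way. With compound 3 unmeasured, the expectation for compound 4 rests on the level set by compound 1 and compound 2 and on the change from (2-methoxyethyl)amino to isopropyl(methyl)amino, and no step beyond the scatter can be assigned in either direction. Compound 4 is therefore expected to sit near 0.01, with a plausible range from 0.004 to 0.025.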

Compound 4, unbound fraction: 0.002
The estimate for compound 4 lay 5.0-fold (0.70 log units) above the measured number; the whole stated range lies above it.
By their numbers in this assay, from the lowest: compound 4; then compounds 2 and 1 (each within the scatter of the next).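

In this assay, for the compounds shown here, compound 4 gives 0.002 while compound 3 has no single number, so no step from compound 3 to compound 4 can be read. Nothing in hand accounts for the value of compound 4. The compounds shown leave open how isopropyl(methyl)amino and (2-methoxyethyl)amino on the sulfonyl sulfur compare in free fraction.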